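The compounds below may be only part of what the source reports. "The series", "measured", "known", "first", "only" and "open" are said of these compounds alone.

Compound 1 `CC(=NNC(=S)Nc1ccc(I)cc1)c1ccccn1` gives 59 nM in a functional assay on U-87MG ATCC cells (Homo sapiens) for cytotoxicity, read by MTT assay, with a stated time of 48 h; a lower number here means a stronger inhibitor, a higher number a weaker inhibitor.
Compound 2 `CC(=NNC(=S)Nc1ccc(F)cc1)c1ccccn1` gives 10 nM in this assay.

For the measured compounds named here, compound 2 stands at the lowest of the two numbers; the only measured step, a 5.9-fold lower number from compound 1 to compound 2 (0.77 log units; beyond the scatter), separates it from compound 1. Compound 3 `C/C(=N/NC(=S)Nc1ccc(F)cc1)c1ccccn1` is the next compound. Its difference from compound 2: the two compounds have the same atoms and bonds; at least one stereo element is drawn with a configuration in one of them and without one in the other: 1 of 1 stereo elements differ; a double bond is drawn without a configuration in compound 2 and Z in compound 3. Going by the values given here, no measured step involves a change of this kind; the measured step swaps one halogen for another and so does not bear on it. With the atoms and bonds unchanged, the step expected is no change at the digits printed from compound 2 to compound 3 (within the scatter), none beyond the scatter. Compound 3 is therefore estimated to give 10 nM, within a range from 4 nM to 25 nM.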

Compound 3, half-maximal inhibitory concentration: 10 nM
The estimate for compound 3 equals the measured number at the digits printed, within the range that was stated.
By their numbers in this assay, from the lowest: compounds 2 and 3 (each within the scatter of the next); then compound 1.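

This pair tests a different kind of change from the earlier halogen swap: the atoms and bonds stay the same, and only the drawing of one double bond differs. In this assay, specifying that double bond as Z gives no change at the digits printed from compound 2 to compound 3 (within the scatter). The two entries therefore cannot be told apart by their numbers, and the only difference between them lies in how they are drawn: the fact that one of compounds 2 and 3 is drawn with a defined configuration and the other without, at the place where they differ

Still open, from the compounds shown here alone, is how a double bond drawn as E would compare. Also open, going by these compounds, is what a methoxy group or an amine would give in place of the fluoro on the aromatic carbon.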